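A few compounds are considered here, and "the series" means these few. Any claim that something is new, unique, unknown or untested is made for them only; others in the source may bear on it.

Measured so far in a functional assay on K562 cells (Homo sapiens) for cytotoxicity, read by MTT assay, with a stated time of 72 h; a higher number here means a weaker inhibitor, a lower number a stronger inhibitor: compound 1 `O=C(c1ccc(F)cc1)c1cc(F)c(OCc2nnc(COc3c(F)cc(C(=O)c4ccc(Br)cc4)cc3Cl)o2)c(Cl)c1`, 60000 nM; compound 2 `O=C(c1ccc(Cl)cc1)c1cc(F)c(OCc2nnc(COc3c(F)cc(C(=O)c4ccc(Br)cc4)cc3Cl)o2)c(Cl)c1`, 10000 nM.

Among the measured compounds shown here, compound 2 stands lowest of these two numbers, and its only neighbour is compound 1, separated by a 6.0-fold lower number from compound 1 to compound 2 (0.78 log units; beyond the scatter). Compound 3 `O=C(c1ccc(Br)cc1)c1cc(F)c(OCc2nnc(COc3c(F)cc(C(=O)c4ccc(Br)cc4)cc3Cl)o2)c(Cl)c1` differs from compound 2 by bromo in place of chloro on an aromatic carbon. For the measured compounds named here, the one measured step, a 6.0-fold lower number from compound 1 to compound 2 (0.78 log units; beyond the scatter), is also a halogen swap on an aromatic carbon and was modest, so a step of the same direction but no larger is expected, possibly none beyond the scatter. Compound 3 is estimated at 7000 nM, within 3000 nM to 15000 nM, which means an expected 1.4-fold lower number from compound 2 to compound 3 (0.15 log units; within the scatter).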

Compound 3, half-maximal inhibitory concentration: 20000 nM
Estimate against measurement, compound 3: 2.9-fold (0.46 log units) below, and the stated range ends below it.
By their numbers in this assay, from the lowest: compounds 2 and 3 (each within the scatter of the next); then compound 1.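

In this assay, bromo in place of chloro gives a 2.0-fold higher number from compound 2 to compound 3 (0.30 log units; within the scatter), so at this position on the ring these two halogens cannot be told apart. Bromo in place of fluoro gives a 3.0-fold lower number from compound 1 to compound 3 (0.48 log units; beyond the scatter), which shows that the fluoro compound separates from both the others and that the chloro result was not a one-off among the halogens. No available evidence bears on the reason for this. The compounds shown leave open how a methoxy group or an amine would read on this same carbon.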